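This account rests on a few compounds, and the source may have more. Where it says the series, first, only, none or still open, it means among the compounds named here.

Measured compounds in a functional assay on B16 cells (Mus musculus) for cytotoxicity, read by MTT assay, with a stated time of 72 h; on this read-out higher numbers stand for weaker inhibition and lower numbers for stronger inhibition:
compound 1 `COc1ccc(/C=C/C(=O)Nc2cc(C(=O)c3cc(OC)c(OC)c(OC)c3)ccc2OC)cc1`: 8700 nM
compound 2 `C#CCOc1cccc(/C=C/C(=O)Nc2cc(C(=O)c3cc(OC)c(OC)c(OC)c3)ccc2OC)c1`: 12200 nM
compound 3 `COc1ccc(C(=O)c2cc(OC)c(OC)c(OC)c2)cc1NC(=O)/C=C/c1ccc(F)cc1`: 400 nM

Compound 3 gives the lowest number of the three, and both of its steps to the others lie beyond the scatter: a 22-fold lower number from compound 1 to compound 3 (1.34 log units; beyond the scatter) and a 31-fold lower number from compound 2 to compound 3 (1.48 log units; beyond the scatter). Between compound 1 and compound 2 the step is a 1.4-fold higher number from compound 1 to compound 2 (0.15 log units; within the scatter), so the two groups on the double-bonded chain carbon in those compounds cannot be told apart on this read-out.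

Compound 4 `COc1ccc(C(=O)c2cc(OC)c(OC)c(OC)c2)cc1NC(=O)/C=C/c1cccc(OC(F)(F)F)c1` is not yet measured. The change from compound 3 is 3-(trifluoromethoxy)phenyl in place of 4-fluorophenyl on a double-bonded chain carbon bound to a double-bonded chain carbon. Within the data shown here, two measured steps bear on it. The step of a 31-fold lower number from compound 2 to compound 3 (1.48 log units; beyond the scatter) replaced 3-(propargyloxy)phenyl with 4-fluorophenyl and lowered the number strongly; compound 4 runs the other way, leaving 4-fluorophenyl for 3-(trifluoromethoxy)phenyl. The step of a 22-fold lower number from compound 1 to compound 3 (1.34 log units; beyond the scatter) likewise shows that only the 4-fluorophenyl compound reaches the low number. Among the measured compounds shown here, no measured step covers trifluoromethoxy itself, so the size of the rise is uncertain. A clear step upward, beyond the scatter but possibly short of a full return to the level of compound 1 and compound 2, is expected: a 7.5-fold higher number from compound 3 to compound 4 (0.88 log units; beyond the scatter). Compound 4 is therefore estimated at 3000 nM, with a range from 800 nM to 12000 nM.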

Compound 4, half-maximal inhibitory concentration: 6300 nM
Compound 4: middle estimate off by 2.1-fold (0.32 log units), on the low side, within the range that was stated.
By their numbers in this assay, from the lowest: compound 3; then compounds 4, 1 and 2 (each within the scatter of the next).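

In this assay, a 16-fold higher number from compound 3 to compound 4 (1.20 log units; beyond the scatter) shows that the low number of compound 3 does not carry over to every fluorine-bearing phenyl group on a double-bonded chain carbon bound to a double-bonded chain carbon. Compound 4 instead joins the higher group, with a 1.9-fold lower number from compound 2 to compound 4 (0.29 log units; within the scatter) and a 1.4-fold lower number from compound 1 to compound 4 (0.14 log units; within the scatter), so 3-(trifluoromethoxy)phenyl, 3-(propargyloxy)phenyl and 4-methoxyphenyl cannot be told apart on this read-out, and among the compounds shown only 4-fluorophenyl stands apart. Nothing measured alongside these numbers accounts for that separation.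

Since 3-(trifluoromethoxy)phenyl differs from 4-fluorophenyl in both the group and its place on the ring, the compounds shown leave open whether the low number follows the fluoro group itself or the place it occupies, although 4-methoxyphenyl in compound 1 shows that the place alone does not bring the low number. Also open, from the compounds shown here alone, is how a chloro group, a nitrile or an amine would read in place of the fluoro group of 4-fluorophenyl, with the rest of compound 3 unchanged.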